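A few compounds are considered here, and "the series" means these few. Any claim that something is new, unique, unknown or untested is made for them only; others in the source may bear on it.

Of the compounds shown here, two have been measured in an ADME assay on MCF-10A cells (Homo sapiens) for cytotoxicity, read by sulforhodamine B assay, with a stated time of 72 h, tested at 30 uM; on this read-out lower numbers stand for a weaker effect and higher numbers for a stronger effect at the one concentration tested. Compound 1, `COc1ccc(O)c(/C=C/C(=O)c2ccc(Cl)cc2)c1`, gives 48%. Compound 2, `COc1cc(Br)cc2c1OC(N)=C(C#N)C2CC(=O)c1ccccc1`, gives 45.9%, and the gap between compound 2 and compound 1 lies within the scatter of repeated measurements, so the two read as alike. Compound 3, `COc1cccc(C(=O)CC2C(C#N)=C(N)Oc3c(OC)cc(Br)cc32)c1`, differs from compound 2 by a single change: methoxy in place of hydrogen on an aromatic carbon. For the measured compounds named here, no measured pair shows what such a change does here, so the expectation rests on compound 2 alone. The step from compound 2 to compound 3 in this assay is expected to be small, a number 2.1 percentage points higher from compound 2 to compound 3 (within the scatter), in no particular direction beyond the scatter. Compound 3 is therefore estimated at 48%, within a range of 30% to 65%.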

Compound 3, a percentage reported as activity, at one concentration (the size of the read-out at that concentration, not a potency): 46.3%
The estimate for compound 3 lay 1.7 percentage points above the measured number; low and high end bracket the measured number.
By their numbers in this assay, from the lowest: compounds 2, 3 and 1 (each within the scatter of the next).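

Placing a methoxy group on this aromatic ring, the change from phenyl to 3-methoxyphenyl, gives in this assay a number 0.4 percentage points higher from compound 2 to compound 3 (within the scatter). For the compounds shown here, this is the first measured step at this position, and it shows that this one added group leaves the read-out indistinguishable from that of the unsubstituted ring. No available measurement offers an explanation for this result. From the compounds shown here alone, whether an amine or a carboxylic acid in the same place would shift the read-out remains open. So does whether methoxy on another carbon of this ring would behave alike.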